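Dropping one chloro from the core of compound 3

This account rests on a few compounds, and the source may have more. Where it says the series, first, only, none or still open, it means among the compounds named here.

The series shares a fused bicyclic core carrying a chloromethylbenzyl group. Compound 1 `ClCc1ccccc1Cn1cnc2c(Cl)ncnc21` places the chloromethyl group on the ortho side of the benzyl ring and bears a single chloro on the core; in a functional assay on SF-539 cells (Homo sapiens) for cytotoxicity, read by sulforhodamine B assay, with a stated time of 48 h (on this read-out lower numbers stand for higher toxicity in this test and higher numbers for lower toxicity in this test), compound 1 gives 55000 nM. Compound 2 `ClCc1cccc(Cn2cnc3ncnc(Cl)c32)c1`, the regioisomer with the chloromethyl group in the meta position, has no reported result: in this assay compound 2 gives "not determined" (no result reported). Compound 3 `ClCc1ccc(Cn2cnc3nc(Cl)nc(Cl)c32)cc1` combines the para arrangement with two chloro groups on the core, and in this assay compound 3 gives 5880 nM, the lower of the two numbers recorded so far; compound 1 is the nearest entry, and its number lies well beyond the usual scatter above that of compound 3.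

Compound 4 `ClCc1ccc(Cn2cnc3ncnc(Cl)c32)cc1` keeps the para-substituted benzyl group of compound 3 but differs in one place: hydrogen in place of chloro on an aromatic carbon. Going by the values given here, compound 1, which likewise carries only one chloro on the core, sits at a considerably higher number than compound 3, though it also differs in the benzyl substitution, so no clean step is available for this single change. Removing a chloro is expected to shift the result toward higher numbers by a moderate margin, beyond the scatter, with a step of a 2.6-fold higher number from compound 3 to compound 4 (0.41 log units; beyond the scatter). Compound 4 is therefore estimated at 15000 nM, with a range from 5000 nM to 50000 nM.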

Compound 4, concentration lethal to 50% of the cells: 6760 nM
The estimate for compound 4 lay 2.2-fold (0.35 log units) above the measured number, within the range that was stated.
By their numbers in this assay, from the lowest: compounds 3 and 4 (each within the scatter of the next); then compound 1.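

In this assay the exchange of chloro for hydrogen on the aromatic carbon between two ring nitrogen atoms amounts to a 1.1-fold higher number from compound 3 to compound 4 (0.06 log units; within the scatter) and so gives no distinction between the two compounds in this read-out. Going by these compounds alone, the earlier compounds could not show this, since compound 1 carries one chloro on the core but also differs from compound 3 in the benzyl substitution; this pair is the first to isolate the change, and with everything else held constant, the chloro at this carbon can be lost without a shift beyond the scatter. No supporting data are available that would explain this outcome.

The compounds shown place only chloro or hydrogen on this carbon, so it remains open whether an amine, a methoxy group or a longer chain there would leave the number just as unmoved. The chloromethyl group is also present in every compound shown, which leaves open how the number would respond if a hydroxymethyl group or a plain methyl group stood in its place.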